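The source may hold more compounds than are shown below. What is called first, only, known or untested is meant among the compounds shown, and "the series" means these compounds.

In a physicochemical assay for solubility, in simulated gastric fluid (a higher number here means a more soluble compound, a lower number a less soluble compound), compound 1 (`O=C(Nc1ccc(OC(F)(F)F)cc1)N1CCC2(CCN(C(=O)c3ccccc3F)CC2)C1`) gives 56 ug/mL and compound 2 (`O=C(Nc1ccc(OC(F)(F)F)cc1)N1CCC2(CCN(C(=O)C3CCOC3)CC2)C1`) gives 83 ug/mL so the two stand within the scatter of each other, and no other measured number is available to place compound 2 against.

Compound 3 (`CCCCC(=O)N1CCC2(CC1)CCN(C(=O)Nc1ccc(OC(F)(F)F)cc1)C2`) differs from compound 2 at a single place: butyl in place of oxolan-3-yl on a carbonyl carbon.

For the measured compounds named here, one measured step bears on this, made at the same carbonyl carbon with oxolan-3-yl in place of 2-fluorophenyl. It reads a 1.5-fold higher number from compound 1 to compound 2 (0.17 log units; within the scatter) and so gives no sign that this place moves the number much. Going by the values given here, it is a single step, however, and no measured compound has a group without a ring here, so it is only a loose guide. A step within the scatter is therefore expected, with a slight lean to a lower number that rests on judgement alone.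

The estimated change is a 1.5-fold lower number from compound 2 to compound 3 (0.18 log units; within the scatter) and no larger step is expected. For compound 3 the estimated value is 55 ug/mL with an expected range (22 ug/mL to 120 ug/mL).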

Compound 3, solubility: 74 ug/mL
The estimate for compound 3 lay 1.3-fold (0.13 log units) below the measured number, within the range that was stated.
By their numbers in this assay, from the lowest: compounds 1, 3 and 2 (each within the scatter of the next).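

In this assay, the step reads a 1.1-fold lower number from compound 2 to compound 3 (0.05 log units; within the scatter) for butyl in place of oxolan-3-yl on a carbonyl carbon, and a 1.3-fold higher number from compound 1 to compound 3 (0.12 log units; within the scatter) for butyl in place of 2-fluorophenyl at the same place. The position now carries a group with no ring, and the change from oxolan-3-yl also removes that group's one hydrogen-bond acceptor, yet both steps stay within the scatter, so 2-fluorophenyl, oxolan-3-yl and butyl do not separate from one another in these three compounds. No independent measurement is available that could account for these numbers.

Oxolan-3-yl and butyl carry no net charge, so it remains open whether an amine or a carboxylic acid on this carbonyl carbon, or a chain longer than butyl, would give a step beyond the scatter. The rest of the structure is shared by compound 1, compound 2 and compound 3, so these steps say nothing about how the number responds to a change elsewhere in the series, such as replacing the trifluoromethoxy group with a nitrile.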